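Compound 3 to compound 4, starting from a limit

A few compounds are considered here, and "the series" means these few. Any claim that something is new, unique, unknown or untested is made for them only; others in the source may bear on it.

In a functional assay on CCRF-CEM cells (Homo sapiens), read by MTT assay, with a stated time of 72 h (a higher number here means a weaker inhibitor, a lower number a stronger inhibitor), compound 3 (`Cc1nc(N)c2c(-c3ccco3)cn([C@@H]3O[C@H](CO)[C@@H](O)[C@H]3O)c2n1`) gives > 100000 nM, which is a limit of the assay and not a number. Compound 1 (`CNc1ncnc2c1c(-c1ccoc1)cn2[C@@H]1O[C@H](CO)[C@@H](O)[C@H]1O`) gives > 20000 nM, also a limit. Compound 2 (`Nc1nc(N)c2c(-c3ccco3)cn([C@@H]3O[C@H](CO)[C@@H](O)[C@H]3O)c2n1`) gives > 20000 nM, again a limit. Compound 3 therefore has no measured potency from which to count, and neither do the other two compounds.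

Compound 4 (`Cc1nc(N)c2c(-c3cc4ccccc4o3)cn([C@@H]3O[C@H](CO)[C@@H](O)[C@H]3O)c2n1`) differs from compound 3 in one group on the shared core: 1-benzofuran-2-yl in place of furan-2-yl on an aromatic carbon.

Going by the values given here, the only measured step, a step that the two limits leave unreadable from compound 2 to compound 3, exchanges amino for methyl at another place and has no size to carry over. Among the compounds with values here, no measured step covers the new change, so the expectation rests only on all three compounds ending at limits in this assay. Weak inhibition is expected to persist, with no clear gain. The expected change, an at least 2.0-fold lower number from compound 3 to compound 4 (0.30 log units; that floor lies within the scatter), is only a rough estimate. For compound 4 the estimated value is 50000 nM, with an expected range of 8000 nM to 150000 nM.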

Compound 4, half-maximal inhibitory concentration: > 20000 nM
Compound 4 ended at the assay's limit (the forecaster's own chance of this, stated with the estimate: 80%); the middle value lies beyond the limit too.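

In this assay compound 4 gives > 20000 nM, a limit of the assay and not a number. Compound 3 gives > 100000 nM, also a limit, so the step between compound 3 and compound 4 cannot be read. The compounds shown leave open whether 1-benzofuran-2-yl in place of furan-2-yl changes potency at all.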